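From phenyl to 4-chlorophenyl in a cytotoxicity test

The source may hold more compounds than are shown below. What is called first, only, known or untested is meant among the compounds shown, and "the series" means these compounds.

Compound 1 `COc1ccc(/C=C2\CCC/C(=C\c3ccccc3[N+](=O)[O-])C2=O)cc1` gives > 400000 nM (a limit of the assay, not a number)
Compound 2 `O=C1/C(=C/c2ccccc2)CCC/C1=C\c1ccc([N+](=O)[O-])cc1` gives 123000 nM (a measured number)

In an ADME assay on HPC cells (Homo sapiens) for cytotoxicity, with a stated time of 24 h (on this read-out lower numbers stand for higher toxicity in this test and higher numbers for lower toxicity in this test), compound 2 stands at 123000 nM as the only number shown. Compound 3 `O=C1/C(=C/c2ccc(Cl)cc2)CCC/C1=C\c1ccc([N+](=O)[O-])cc1` differs from compound 2 in one place chloro in place of hydrogen on an aromatic carbon with chloro in place of hydrogen on an aromatic carbon. Among the measured compounds shown here, no measured pair shows this change, so only a small move towards higher toxicity is expected, close to the scatter. The expected step is a 1.4-fold lower number from compound 2 to compound 3 (0.14 log units; within the scatter) and no larger. Compound 3 is estimated at 90000 nM with 35000 nM to 230000 nM as the expected range.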

Compound 3, half-maximal cytotoxic concentration: 345000 nM
Estimate against measurement, compound 3: 3.8-fold (0.58 log units) below; the measured number lies above the stated range.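

The change from phenyl to 4-chlorophenyl gives a 2.8-fold higher number from compound 2 to compound 3 (0.45 log units; beyond the scatter) in this assay, the first step measured at a single place in this set. At this position, para to a large group, adding chloro therefore moves the read-out towards lower toxicity in this test, not towards higher toxicity. Little room remains above compound 3 on this read-out: the limit of > 400000 nM in this assay, at which 1 of the 3 values shown sits.

The compounds shown leave open whether fluoro, an amine or a carboxylic acid at the same place would move the number the same way. They also leave open whether chloro has this effect when the nitro group sits elsewhere.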